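One Halogen Swap on the Carbamate Benzyl Group

A few compounds are considered here, and "the series" means these few. Any claim that something is new, unique, unknown or untested is made for them only; others in the source may bear on it.

Compound 1 `CCN(Cc1cc(C(F)(F)F)ccc1-c1cc(CC(=O)O)ccc1OC)C(=O)OCc1cc(F)cc(F)c1`: 11 nM
Compound 2 `COc1ccc(CC(=O)O)cc1-c1ccc(C(F)(F)F)cc1CN(C(=O)OCc1ccccc1)C1CC1`: 18 nM
Compound 3 `COc1ccc(CC(=O)O)cc1-c1ccc(C(F)(F)F)cc1CN(C(=O)OCc1ccccc1)C1CCC1`: 19 nM

Of the compounds shown here, three have been measured in an in vitro assay on 293T cells for displacement of a labelled ligand from prostaglandin D2 receptor 2 (Homo sapiens), read by scintillation counting, in the presence of a further agent that is not named here; on this read-out lower numbers stand for stronger inhibition and higher numbers for weaker inhibition. Compound 1 has the smallest of the three numbers, yet its gaps to compound 2 and to compound 3 both lie within the scatter, so no ranking follows from them. Among the compounds with values here, the only one-place step among the measured compounds, a 1.1-fold higher number from compound 2 to compound 3 (0.02 log units; within the scatter), is likewise within the scatter. Compound 4 `CCN(Cc1cc(C(F)(F)F)ccc1-c1cc(CC(=O)O)ccc1OC)C(=O)OCc1cccc(Cl)c1` differs from compound 1 in one place: 3-chlorophenyl in place of 3,5-difluorophenyl on a saturated chain carbon bound to an oxygen next to a carbonyl group. Within the data shown here, no measured step touches this position; compound 2 and compound 3 differ from compound 1 in more than one place, so their values show only that the numbers across this small set sit close together. With nothing in the data pointing either way, the step expected in this assay from compound 1 to compound 4 is small: a 1.3-fold higher number from compound 1 to compound 4 (0.10 log units; within the scatter). Compound 4 is therefore estimated at 14 nM, with a range from 6 nM to 35 nM.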

Compound 4, half-maximal inhibitory concentration: 10 nM
Estimate against measurement, compound 4: 1.4-fold (0.15 log units) above; the range from low to high includes it.
By their numbers in this assay, from the lowest: compounds 4, 1, 2 and 3 (each within the scatter of the next).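

Within the data shown here, at the saturated chain carbon bound to an oxygen next to a carbonyl group, 3-chlorophenyl in place of 3,5-difluorophenyl gives in this assay a 1.1-fold lower number from compound 1 to compound 4 (0.04 log units; within the scatter) and so provides the first measured step at this position. The earlier compounds shown here left this position untested, whereas this pair shows that the two halogen-bearing phenyl groups cannot be told apart on this read-out, with the rest of compound 1 held fixed. No available evidence bears on why the two read alike.

From the compounds shown here alone, how an amine or a carboxylic acid on this phenyl ring, or a longer chain in place of the benzyl group, would read in this assay remains open. Also open, going by these compounds, is whether the same halogen swap would read alike with cyclopropyl or cyclobutyl in place of ethyl on the amide-type nitrogen.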